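A Single Stereocentre Inverted on the Saturated Chain

A few compounds are considered here, and "the series" means these few. Any claim that something is new, unique, unknown or untested is made for them only; others in the source may bear on it.

Within the data shown here, in a physicochemical assay for solubility, measured as kinetic solubility (on this read-out lower numbers stand for lower solubility and higher numbers for higher solubility), compound 1 (`Cc1cc(C)c(CN2CCc3c(Cl)cc([C@H](CO)[C@H]4CCCO4)c(Cl)c3C2=O)c(=O)[nH]1`) gives 430000 nM, the only single number for it. Compound 2 (`COc1cc(C)[nH]c(=O)c1CN1CCc2c(Cl)cc(C(OC)C3CCN(C(=O)CO)CC3)c(Cl)c2C1=O`), a further relative, gives 480000 nM; 453000 nM (2 entries), and the two values lie within the scatter of each other. Compound 3 (`Cc1cc(C)c(CN2CCc3c(Cl)cc([C@@H](CO)[C@H]4CCCO4)c(Cl)c3C2=O)c(=O)[nH]1`) differs from compound 1 by the two compounds have the same atoms and bonds and differ only in configuration as drawn: 1 of 2 stereo elements differ; a stereocentre at a saturated chain carbon is drawn R in compound 1 and S in compound 3; the two have the same atoms and bonds. Among the measured compounds shown here, no measured pair shows what such an inversion does, so no change beyond the scatter is expected in this assay, in either direction. The estimated step is a 1.0-fold lower number from compound 1 to compound 3 (0.01 log units; within the scatter). For compound 3 the expected value is 420000 nM, with an estimated range from 210000 nM to 750000 nM.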

Compound 3, solubility: 576000 nM
For compound 3 the middle estimate is 1.4-fold (0.14 log units) below the measured one; low and high end bracket the measured number.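

Among these compounds, this pair gives the first reading of such an inversion: in this assay, the stereocentre at a saturated chain carbon drawn R and then S amounts to a 1.3-fold higher number from compound 1 to compound 3 (0.13 log units; within the scatter). At this position, then, the configuration as drawn leaves the read-out within the scatter. The comparison rests on a single change: the fact that compounds 1 and 3 differ only in the configuration as drawn.

The compounds shown leave open whether inverting the second stereo element would behave alike. They also leave open whether a carboxylic acid or an amine on the saturated chain would give a step beyond the scatter.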